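The source may report more compounds than this note shows. Statements on the series, on what has been measured and on what is new or still open speak of the compounds shown alone.

In a functional assay on MCF7 cells (Homo sapiens) for inhibition, read by sulforhodamine B assay, with a stated time of 48 h (a higher number here means a weaker inhibitor of growth, a lower number a stronger inhibitor of growth), compound 1 `c1ccc(COc2cccc(NC3=NCCO3)c2)cc1` gives 2600 nM. Compound 2 `O=C(CCl)NC(=O)Nc1cccc(OC2CCCCC2)c1` gives 6300 nM, and compound 3 `O=C(CCl)NC(=O)Nc1cccc(OC2CCCCCC2)c1` gives 7200 nM, within the scatter of compound 2 and a higher number than compound 1. Compound 4 `O=C(CCl)NC(=O)Nc1cccc(OCc2ccccc2)c1` differs from compound 3 by benzyl in place of cycloheptyl on an oxygen on an aromatic ring. Going by the values given here, the one measured step at this place, a 1.1-fold higher number from compound 2 to compound 3 (0.06 log units; within the scatter), exchanges one non-aromatic ring for another, so it bears on the change only in part. Compound 1, at 2600 nM, also carries benzyl, but on a different core. No step beyond the scatter is therefore expected, and the estimated change is a 1.4-fold lower number from compound 3 to compound 4 (0.16 log units; within the scatter). Compound 4 is expected at 5000 nM, within an estimated range of 2500 nM to 10000 nM.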

Compound 4, concentration for 50% growth inhibition: 6200 nM
For compound 4 the middle estimate is 1.2-fold (0.09 log units) below the measured one; the measured number falls inside the stated range.
By their numbers in this assay, from the lowest: compound 1; then compounds 4, 2 and 3 (each within the scatter of the next).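

In this assay, an aromatic ring on this oxygen makes no difference that can be read, whether benzyl replaces cycloheptyl (a 1.2-fold lower number from compound 3 to compound 4 (0.06 log units; within the scatter)) or cyclohexyl (a 1.0-fold lower number from compound 2 to compound 4 (0.01 log units; within the scatter)). With benzyl held fixed, the group on the nitrogen on the aromatic ring does matter modestly (a 2.4-fold higher number from compound 1 to compound 4 (0.38 log units; beyond the scatter)), a change beyond the scatter. No measured evidence bears on the reason for these numbers. The compounds shown leave open whether an amine or a carboxylic acid on the benzyl ring would move the number. They also leave open whether a longer chain on this oxygen would do so.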